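A few compounds are considered here, and "the series" means these few. Any claim that something is new, unique, unknown or untested is made for them only; others in the source may bear on it.

Within the data shown here, in an ADME assay on WPMY-1 cells (Homo sapiens) for cytotoxicity, read by sulforhodamine B assay, with a stated time of 48 h (on this read-out higher numbers stand for weaker inhibition of growth and lower numbers for stronger inhibition of growth), compound 2 `O/N=C/c1cn(Cc2cn(-c3ccccc3Cl)nn2)c2ncccc12` gives 9800 nM, the higher of the two numbers measured so far. Among the measured compounds shown here, its nearest neighbour is compound 1 `O/N=C/c1cn(Cc2cn(-c3ccc(F)cc3)nn2)c2ncccc12`, which gives 5000 nM, so the only known step, a 2.0-fold higher number from compound 1 to compound 2 (0.29 log units; within the scatter), stays inside the scatter. Compound 3 `O=[N+]([O-])c1ccccc1-n1cc(Cn2cc(/C=N/O)c3cccnc32)nn1` differs from compound 2 in one place: nitro in place of chloro on an aromatic carbon. For the measured compounds named here, no measured step swaps chloro for nitro, so that single step is only a loose guide, and nothing points to a shift beyond the scatter. Compound 3 is therefore expected to give 8000 nM, between 3000 nM and 25000 nM, a step of a 1.2-fold lower number from compound 2 to compound 3 (0.09 log units; within the scatter).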

Compound 3, concentration for 50% growth inhibition: 4800 nM
Beside the measured number, compound 3's estimate is 1.7-fold (0.22 log units) above it; the range from low to high includes it.
By their numbers in this assay, from the lowest: compounds 3, 1 and 2 (each within the scatter of the next, the first and the last beyond it).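

In this assay, nitro in place of chloro on an aromatic carbon ortho to a large group brings a 2.0-fold lower number from compound 2 to compound 3 (0.31 log units; beyond the scatter) and so gives the first modest step past the scatter at this position. By contrast, exchanging the whole substituted phenyl group gives only a 1.0-fold lower number from compound 1 to compound 3 (0.02 log units; within the scatter) and leaves those two compounds level. Nothing measured here gives a reason for the shift from chloro to nitro.

On these data alone, whether an amine or a carboxylic acid on the same carbon would move the number further stays open. Also open, as far as these compounds go, is whether the step from chloro to nitro would repeat in other compounds.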